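The compounds below may be only part of what the source reports. "The series", "measured", "known", "first", "only" and "open" are said of these compounds alone.

Three compounds on the shared core have been run in a functional assay on cells (Cancer cell lines, Homo sapiens) for cytotoxicity; on this read-out higher numbers stand for an effect only at larger amounts of compound and lower numbers for an effect already at smaller amounts. Compound 1 `Nc1nc(O)c2nnn(C3CC(CO)C(O)C3O)c2n1` reaches only the limit > 100 ug/mL in this assay. Compound 3 `Nc1nc(N)c2nnn(C3CC(CO)C(O)C3O)c2n1` likewise stands at the limit > 100 ug/mL, so on the numbers shown it sits at the unmeasured high end, as the limit of > 100 ug/mL in this assay, at which 2 of the 3 values shown sit, records. Going by the values given here, compound 2 `Nc1nc(Cl)c2nnn(C3CC(CO)C(O)C3O)c2n1` gives 8 ug/mL and is the one compound with a readable number. The measured steps are an at least 12-fold lower number from compound 1 to compound 2 (1.09 log units; beyond the scatter), an at least 12-fold higher number from compound 2 to compound 3 (1.09 log units; beyond the scatter) and a step that the two limits leave unreadable from compound 1 to compound 3.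

Compound 4 `CSc1nc(N)nc2c1nnn2C1CC(CO)C(O)C1O` differs from compound 3 by methylsulfanyl in place of amino on an aromatic carbon. Among the compounds with values here, no measured step exchanges amino for methylsulfanyl, so the bearing is indirect: the step of an at least 12-fold higher number from compound 2 to compound 3 (1.09 log units; beyond the scatter) shows that an exchange at this carbon can move the number beyond the scatter, while the step that the two limits leave unreadable from compound 1 to compound 3 shows that not every exchange there yields a readable number. Methylsulfanyl is neither chloro nor hydroxy, and the direction in this assay cannot be read from the series. A modest downward step from the limit is expected, as an at least 2.5-fold lower number from compound 3 to compound 4 (0.39 log units; beyond the scatter). Compound 4 is estimated at 40 ug/mL, between 8 ug/mL and 200 ug/mL, with a real chance that only a limit is returned again.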

Compound 4, concentration for half-maximal effect: > 100 ug/mL
Compound 4 was reported as a limit; the forecaster's own chance of this, stated with the estimate: 45%; middle value at least 2.5-fold (0.39 log units) from the limit.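

Measured in this assay the exchange of chloro for methylsulfanyl gives an at least 12-fold higher number from compound 2 to compound 4 (1.09 log units; beyond the scatter) and places methylsulfanyl with hydroxy and amino, away from chloro, at this aromatic carbon. Of the four groups shown on this carbon, chloro alone gives a readable number, so methylsulfanyl in place of amino does not bring the series back to a readable value. The steps among compound 1, compound 3 and compound 4 cannot be read, as each joins two limits, and the read-out now gathers at one end: the limit of > 100 ug/mL in this assay, at which 3 of the 4 values shown sit.

From the compounds shown here alone, how compound 1, compound 3 and compound 4 rank beyond that limit remains open. Also open, going by these compounds, is whether the readable number is peculiar to chloro or is shared by bromo, methoxy or a longer chain such as ethylsulfanyl at this carbon.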